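Methyl in place of methoxy: what to expect of compound 4

A few compounds are considered here, and "the series" means these few. Any claim that something is new, unique, unknown or untested is made for them only; others in the source may bear on it.

Of the compounds shown here, three sharing one core have been measured in a functional assay on HeLa cells (Homo sapiens) for cytotoxicity, read by MTT assay, with a stated time of 48 h; a lower number here means a stronger inhibitor, a higher number a weaker inhibitor. Compound 1 `C=C1CCC[C@]2(C)CCC(c3cn(-c4ccc(OC)cc4)nn3)=CC[C@@]12C` gives 43600 nM, the second highest of the three numbers. Compound 2 `C=C1CCC[C@]2(C)CCC(c3cn(-c4ccc(C(C)=O)cc4)nn3)=CC[C@@]12C` gives 15100 nM, and compound 3 `C=C1CCC[C@]2(C)CCC(c3cn(-c4ccc(I)cc4)nn3)=CC[C@@]12C` gives 144000 nM. Compound 4 `C=C1CCC[C@]2(C)CCC(c3cn(-c4ccc(C)cc4)nn3)=CC[C@@]12C` has not yet been measured. It differs from compound 1 by methyl in place of methoxy on an aromatic carbon, para to a large group (methyl in place of methoxy on an aromatic carbon).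

Two measured steps replace the same methoxy. Acetyl in its place gives a 2.9-fold lower number from compound 1 to compound 2 (0.46 log units; beyond the scatter), while iodo in its place gives a 3.3-fold higher number from compound 1 to compound 3 (0.52 log units; beyond the scatter). These modest steps run in opposite directions, and the gap between the two replacements is a 9.5-fold higher number from compound 2 to compound 3 (0.98 log units; beyond the scatter). For the measured compounds named here, none of the three compounds carries methyl, so the data offer no direct precedent and no firm direction. Compound 4 is therefore expected to stay close to compound 1, with no step beyond the scatter, although a modest step either way cannot be excluded. The estimated change is a 1.1-fold higher number from compound 1 to compound 4 (0.06 log units; within the scatter). The expected value for compound 4 is 50000 nM, with an estimated range from 22000 nM to 120000 nM.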

Compound 4, half-maximal inhibitory concentration: 69100 nM
Compound 4: the middle estimate sits 1.4-fold (0.14 log units) below what was measured; low and high end bracket the measured number.
By their numbers in this assay, from the lowest: compound 2; then compounds 1 and 4 (each within the scatter of the next); then compound 3.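

In this assay, for the compounds shown here, methyl is the first replacement of methoxy at this place whose step stays within the scatter: the result is a 1.6-fold higher number from compound 1 to compound 4 (0.20 log units; within the scatter). The oxygen, and with it the one hydrogen-bond acceptor of methoxy, can therefore go without a step that can be read beyond the scatter, so 4-methoxyphenyl and 4-methylphenyl are not separated by this measurement. The other two groups do stand apart from methyl, with a 4.6-fold higher number from compound 2 to compound 4 (0.66 log units; beyond the scatter) on the acetyl side and a 2.1-fold lower number from compound 3 to compound 4 (0.32 log units; beyond the scatter) on the iodo side, so the four groups at this place form three levels: compound 2 at the low end, compounds 1 and 4 together in the middle, and compound 3 at the high end.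

Nothing shown accounts for why acetyl and iodo part from the middle pair. Going by these compounds, whether an amine, a carboxylic acid or a longer chain at this place would join compound 2, compound 3 or the middle pair stays open, as does whether these steps would hold on a different core or in a different cell line.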